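Methoxy for Fluoro on a Quinoline Ester and Ether

A few compounds are considered here, and "the series" means these few. Any claim that something is new, unique, unknown or untested is made for them only; others in the source may bear on it.

Measured compounds, in a functional assay on MDA-MB-231 cells (Homo sapiens) for antiproliferative activity, read by MTT assay, with a stated time of 48 h; a lower number here means a stronger inhibitor, a higher number a weaker inhibitor:
compound 1 `Cc1ccc2nc(-c3ccc(F)cc3)cc(C(=O)OCc3ccccc3)c2c1` gives 13200 nM;
compound 2 `COc1ccc(-c2cc(C(=O)OCc3ccccc3)c3cc(C)ccc3n2)cc1` gives 20500 nM;
compound 3 `Cc1ccc2nc(-c3ccc(F)cc3)cc(COCc3ccccc3)c2c1` gives > 100000 nM, which is a limit of the assay rather than a number.

Compound 1 and compound 2 differ by methoxy in place of fluoro on an aromatic carbon. In this assay that step reads a 1.6-fold higher number from compound 1 to compound 2 (0.19 log units; within the scatter). How the core of compound 3 differs from the core of compound 1 is not broken down here. Compound 4 `COc1ccc(-c2cc(COCc3ccccc3)c3cc(C)ccc3n2)cc1` has not yet been measured; it differs from compound 3 by methoxy in place of fluoro on an aromatic carbon, the same change as from compound 1 to compound 2, at the same place.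

For compound 4 the step in this assay is expected to be about a step that the limit leaves unreadable from compound 3 to compound 4, beside the measured step from compound 1 to compound 2, because compound 3 sits at the limit of > 100000 nM in this assay, at which 1 of the 3 values shown sits. Compound 4 is therefore expected to give roughly 150000 nM, most likely again reported only as a limit, with a range from 70000 nM to 400000 nM.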

Compound 4, half-maximal inhibitory concentration: > 100000 nM
Compound 4: a limit, no number (the forecaster's own chance of this, stated with the estimate: 85%); the middle value is on the limit's open side.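

No step from compound 3 to compound 4 can be read, since in this assay each is reported only as a limit of the assay, not as a number: the limit of > 100000 nM in this assay, at which 2 of the 4 values shown sit.

Left open is what numbers compound 3 and compound 4 would actually give, and whether methoxy in place of fluoro changes anything between them.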